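The source may hold more compounds than are shown below. What is called first, only, known or untested is meant among the compounds shown, and "the series" means these compounds.

Measured so far:
compound 1, `CCCc1cn(C(c2ccccc2)c2ccccc2)nn1`, 11000 nM in an assay on isolated protein for inhibition of Aromatase (Homo sapiens), read by fluorescence and colorimetric assay, with a stated time of 30 min; on this read-out higher numbers stand for weaker inhibition and lower numbers for stronger inhibition
compound 2, `c1ccc(OCc2cn(C(c3ccccc3)c3ccccc3)nn2)cc1`, 31300 nM in this assay

Compound 2 gives the highest number of the two in this assay; its nearest neighbour is compound 1, and the step of a 2.8-fold higher number from compound 1 to compound 2 (0.45 log units; beyond the scatter) goes beyond the scatter, so compound 2 is the weaker inhibitor of the pair. Compound 3, `O=[N+]([O-])c1ccc(OCc2cn(C(c3ccccc3)c3ccccc3)nn2)cc1`, has not yet been measured. It differs from compound 2 by one change: nitro in place of hydrogen on an aromatic carbon, which leaves the rest of the molecule untouched. Among the compounds with values here, no measured step involves a nitro group or any change on the phenoxy ring; the only step in hand, from compound 1 to compound 2, swapped the whole side chain and so says little about this smaller change. Without a bearing step, no movement beyond the scatter is expected. Compound 3 is therefore estimated at 25000 nM, with a range from 8000 nM to 80000 nM, meaning an expected step of a 1.3-fold lower number from compound 2 to compound 3 (0.10 log units; within the scatter).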

Compound 3, half-maximal inhibitory concentration: 11600 nM
Estimate against measurement, compound 3: 2.2-fold (0.33 log units) above; the measured number falls inside the stated range.
By their numbers in this assay, from the lowest: compounds 1 and 3 (each within the scatter of the next); then compound 2.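

Turning the phenyl of compound 2 into the 4-nitrophenyl of compound 3 gives a 2.7-fold lower number from compound 2 to compound 3 (0.43 log units; beyond the scatter) in this assay, so inhibition responds to a change on this outer ring. The earlier step could not show this, as it replaced the whole side chain rather than altering one aromatic carbon. Here a single nitro group, placed para to a large group, moves the number by a modest amount that still lies beyond the scatter, although nothing available explains the shift.

Going by these compounds, with only one substituent at one place on this ring, it remains open whether an amine, a methoxy group or a carboxylic acid there would shift the number in the same direction or by as much. On these data alone, it also remains open whether the nitro group would give a similar step elsewhere on the ring.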